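This account rests on a few compounds, and the source may have more. Where it says the series, first, only, none or still open, it means among the compounds named here.

In a functional assay on PC-3 cells (Homo sapiens) for inhibition, read by sulforhodamine B assay, with a stated time of 48 h, tested at 50 uM (a higher number here means more inhibition of growth at the concentration tested, a lower number less inhibition of growth), compound 2 `COc1ccc([C@@H]2C/C(=N/OCc3cn(-c4ccc(C(N)=O)cc4)nn3)c3cc(CC=C(C)C)c(OC)cc3O2)cc1` gives 100% and stands highest of the two numbers, above compound 1 `COc1ccc([C@@H]2C/C(=N/OCc3cn(-c4ccc(C#N)cc4)nn3)c3cc(CC=C(C)C)c(OC)cc3O2)cc1` at 50% in the same test. Compound 3 `COc1ccc([C@@H]2C/C(=N/OCc3cn(-c4cccnc4Cl)nn3)c3cc(CC=C(C)C)c(OC)cc3O2)cc1` brings one change, 2-chloropyridin-3-yl in place of 4-carbamoylphenyl on an aromatic nitrogen. For the measured compounds named here, only one measured step bears on it, the large a number 50 percentage points higher from compound 1 to compound 2 (beyond the scatter) for carbamoyl in place of cyano on an aromatic carbon. Going by the values given here, compound 3 lacks the carbamoyl too, and its new group has no measured precedent. In this assay a fall of similar size is therefore expected, with the estimate being a number 45 percentage points lower from compound 2 to compound 3 (beyond the scatter) overall. For compound 3 an estimated 55% is expected, within a range from 25% to 90% for now.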

Compound 3, percent growth inhibition at one concentration: 44%
Compound 3: middle estimate off by 11 percentage points, on the high side; measured number inside the range.
By their numbers in this assay, from the lowest: compounds 3 and 1 (each within the scatter of the next); then compound 2.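

In this assay, the whole aryl group on the aromatic nitrogen of the five-membered ring can be exchanged, and 2-chloropyridin-3-yl in place of 4-carbamoylphenyl gives a number 56 percentage points lower from compound 2 to compound 3 (beyond the scatter). Against the nitrile, the same group gives a number 6 percentage points lower from compound 1 to compound 3 (within the scatter), so of these three compounds only the one with 4-carbamoylphenyl stands apart. Nothing available accounts for this result. As far as these compounds go, it remains open whether a carboxylic acid or an amine on the same phenyl ring would match the carbamoyl. From the compounds shown here alone, it also remains open whether the chlorine or the ring nitrogen of 2-chloropyridin-3-yl matters at all.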